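Sulfanyl variation in a pyrazole sulfonyl guanidine series

The source may report more compounds than this note shows. Statements on the series, on what has been measured and on what is new or still open speak of the compounds shown alone.

Measured so far in a functional assay on HeLa cells (Homo sapiens) for cytotoxicity, read by MTT assay, with a stated time of 72 h; a lower number here means a stronger inhibitor, a higher number a weaker inhibitor:
- compound 1 `Cc1cc(S(=O)(=O)/N=C(\N)n2nccc2-c2ccccc2)c(SCc2ccccc2)cc1Cl`: 5000 nM
- compound 2 `Cc1cc(S(=O)(=O)/N=C(\N)n2nccc2-c2ccccc2)c(SCc2ccc(C(F)(F)F)cc2)cc1Cl`: 17000 nM
- compound 3 `Cc1ccc(CSc2cc(Cl)c(C)cc2S(=O)(=O)/N=C(\N)n2nccc2-c2ccccc2)cc1`: 17000 nM

Compound 3 sits level with compound 2 at the digits shown, the two together giving the highest numbers of the three; compound 1 lies furthest from it, and the step of a 3.4-fold higher number from compound 1 to compound 3 (0.53 log units; beyond the scatter) runs beyond the scatter. The pair compound 2 and compound 3 differ only in the step of no change at the digits printed from compound 2 to compound 3 (within the scatter), which is within the scatter.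

The next compound, compound 4 `Cc1cc(S(=O)(=O)/N=C(\N)n2nccc2-c2ccccc2)c(SCc2ccccc2Cl)cc1Cl`, differs from compound 3 by 2-chlorophenyl in place of 4-methylphenyl on a saturated chain carbon bound to a sulfur. For the measured compounds named here, no measured step puts a chlorine on this ring, so nothing bears directly on the change. What does bear on it is that both substitutions tried so far on this ring, the steps of a 3.4-fold higher number from compound 1 to compound 2 (0.53 log units; beyond the scatter) and a 3.4-fold higher number from compound 1 to compound 3 (0.53 log units; beyond the scatter), gave the same modest rise from compound 1, while the swap between them, no change at the digits printed from compound 2 to compound 3 (within the scatter), changed nothing. A substituted ring of this kind has so far landed near compound 3 rather than near compound 1.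

For compound 4 the number in this assay is therefore expected to stay close to compound 3, with the step of a 1.4-fold lower number from compound 3 to compound 4 (0.15 log units; within the scatter) estimated to fall within the scatter or a little lower. The estimate for compound 4 is 12000 nM, within 4000 nM to 30000 nM.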

Compound 4, half-maximal inhibitory concentration: 19000 nM
Beside the measured number, compound 4's estimate is 1.6-fold (0.20 log units) below it; the measured number falls inside the stated range.
By their numbers in this assay, from the lowest: compound 1; then compounds 2, 3 and 4 (each within the scatter of the next).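

In this assay the 2-chlorophenyl group of compound 4 cannot be told apart from the 4-methylphenyl group (a 1.1-fold higher number from compound 3 to compound 4 (0.05 log units; within the scatter)) or from the 4-(trifluoromethyl)phenyl group (a 1.1-fold higher number from compound 2 to compound 4 (0.05 log units; within the scatter)), so three different substituents, one of them carried at a different ring carbon, all give the same level. Against the unsubstituted phenyl ring of compound 1, the chloro group gives a modest rise (a 3.8-fold higher number from compound 1 to compound 4 (0.58 log units; beyond the scatter)), of about the same size as the two earlier substitutions; among the four compounds, all three substituted rings therefore sit together and only compound 1 stands apart, with no compound going against this. Nothing available here accounts for this shared level or for the gap to compound 1.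

Still open, from the compounds shown here alone, is whether an amine or a carboxylic acid on this ring would stay at the level of compounds 2, 3 and 4 or return toward compound 1. Also open, going by these compounds, is whether a longer chain between the sulfur and the ring would keep the same order, and whether that order holds on any core other than the shared one.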